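When 3-chloro-4-fluorophenyl replaces 4-chlorophenyl: intrinsic activity

The compounds below may be only part of what the source reports. "The series", "measured", "known", "first", "only" and "open" are said of these compounds alone.

Measured compounds:
compound 1, `CC(=O)N1C[C@@H](C(=O)N2CCN(c3ccc(C)cc3[C@@H](NC(=O)CCN(C)C)C(C)C)CC2)[C@H](c2ccc(Cl)cc2)C1`, 100%
compound 2, `CC(C)[C@H](NC(=O)CCN(C)C)c1cccc(F)c1N1CCN(C(=O)[C@@H]2CN(C(C)C)C[C@H]2c2ccc(Cl)cc2)CC1`, 103%

In a functional assay on CHO cells with Melanocortin receptor 4 (Homo sapiens) as the target, read by cAMP accumulation (a higher number here means a larger maximal response, a lower number a smaller maximal response), compound 1 reaches 100%, and compound 2 reaches 103%. Compound 2 stands at the higher of the two numbers, but the gap to compound 1 lies within the usual scatter of repeated measurements, so the two compounds are not distinguished by this read-out; both reach about the full response of the reference agonist.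

Compound 3, `CC(C)[C@H](NC(=O)CCN(C)C)c1cccc(F)c1N1CCN(C(=O)[C@@H]2CN(C(C)C)C[C@H]2c2ccc(F)c(Cl)c2)CC1`, has not been measured in this assay. It differs from compound 2 in one place: 3-chloro-4-fluorophenyl in place of 4-chlorophenyl on a saturated ring carbon. Among the compounds with values here, no step between two measured compounds is available to show what this kind of change does to the maximal response. Given that compound 2 sits at 103% and compound 1 at 100%, the expectation for compound 3 is a maximal response essentially unchanged, with a step of a number 3 percentage points lower from compound 2 to compound 3 (within the scatter) that stays within the scatter. Compound 3 is therefore estimated at 100%, with a range from 85% to 112%.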

Compound 3, intrinsic activity: the largest response reached, in percent of the reference agonist's: 78%
For compound 3 the middle estimate is 22 percentage points above the measured one; measured number below the stated range.
By their numbers in this assay, from the lowest: compound 3; then compounds 1 and 2 (each within the scatter of the next).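

Read in this assay the exchange of 4-chlorophenyl for 3-chloro-4-fluorophenyl, on a saturated ring carbon of the five-membered ring, gives a number 25 percentage points lower from compound 2 to compound 3 (beyond the scatter) and is the first step here between compounds that differ in one place. Within the data shown here, it shows that the maximal response is not fixed at the full level seen in the earlier compounds and that this position can lower it, even though the entering group differs from the leaving one by a single added heavy atom and has the same count of hydrogen-bond donors and acceptors and no net charge. Nothing available explains the fall in maximal response.

Since the chlorine changes its place on the phenyl ring and a fluorine enters in the same step, the compounds shown leave open which of the two goes with the lower response, and 3-chlorophenyl or 4-fluorophenyl at this position would separate them. Also open, on these data alone, is whether the same exchange lowers the response on the core of compound 1, and what a larger substituent such as methoxy or trifluoromethyl on this phenyl ring would do.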